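Homologation of the hydroxymethyl arm on the shared core

The source may hold more compounds than are shown below. What is called first, only, known or untested is meant among the compounds shown, and "the series" means these compounds.

Compound 1, `Cn1cc(C(=O)Nc2ccc(-c3ccccc3)c(C(F)(F)F)c2)c(=O)c2cnccc21`, and compound 2, `Cn1cc(C(=O)Nc2ccc(-c3ccccc3)c(C(F)(F)F)c2)c(=O)c2ccc(CO)cc21`, share the amide and the biaryl bearing the trifluoromethyl group, and differ in the core and in the hydroxymethyl group carried by compound 2. In an ADME assay on LLC-PK1 cells (Sus scrofa) for permeability (on this read-out higher numbers stand for higher permeability and lower numbers for lower permeability), compound 1 gives 5.7 10^-6 cm/s. In this assay compound 2 gives 2.8 10^-6 cm/s, the lower of the two numbers in hand; the gap to compound 1 lies beyond the scatter. For the measured compounds named here, the two compounds differ in more than one place, so the numbers are set side by side and no single step is drawn between them.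

Compound 3, `Cn1cc(C(=O)Nc2ccc(-c3ccccc3)c(C(F)(F)F)c2)c(=O)c2ccc(CCO)cc21`, carries the change (hydroxymethyl in place of hydroxy on a saturated chain carbon bound to an aromatic carbon). The donor and acceptor count is unchanged and the difference is one of chain length alone. Going by the values given here, no measured step of this kind is in hand. Relative to compound 2 at 2.8 10^-6 cm/s, a small step is expected, a 1.1-fold higher number from compound 2 to compound 3 (0.06 log units; within the scatter), likely within the scatter and, if anything, upward. For compound 3 the estimate in this assay is 3.2 10^-6 cm/s, with a range of 1.6 10^-6 cm/s to 6.4 10^-6 cm/s.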

Compound 3, apparent permeability: 2.2 10^-6 cm/s
Estimate against measurement, compound 3: 1.5-fold (0.16 log units) above, within the range that was stated.
By their numbers in this assay, from the lowest: compounds 3 and 2 (each within the scatter of the next); then compound 1.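

In this assay, for the compounds shown here, the change from hydroxymethyl to 2-hydroxyethyl gives a 1.3-fold lower number from compound 2 to compound 3 (0.10 log units; within the scatter) and is the first step that can be read at a single place. On a saturated chain carbon bound to an aromatic carbon, this lengthening of the arm, with the same count of hydrogen-bond donors and acceptors, gives a step that stays within the scatter, so the read-out does not separate compound 2 from compound 3. Nothing in hand bears on the cause of this result.

From the compounds shown here alone, a single step at this position does not establish a trend with chain length, and it remains open whether a longer chain, an amine or a carboxylic acid on the same arm would stay within the scatter of compound 2 or move clearly away from it. The higher number of compound 1 cannot be assigned to its core or to the absence of the arm, as compound 1 differs from compound 2 and compound 3 in more than one place, and a compound with the arm on the core of compound 1 would be needed to separate the two.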